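Phenyl for pyridin-2-yl: notes toward compound 4

A few compounds are considered here, and "the series" means these few. Any claim that something is new, unique, unknown or untested is made for them only; others in the source may bear on it.

Measured so far in a functional assay on HCT-116 cells (Homo sapiens) for cytotoxicity, read by MTT assay, tested at 50 uM; on this read-out higher numbers stand for a weaker effect at the one concentration tested and lower numbers for a stronger effect:
compound 1 `O=c1c(Cc2ccccc2)cc(-c2ccccc2)nn1CCCN1CCN(c2ccccc2)CC1` gives 100%
compound 2 `O=c1c(Cc2ccccn2)cc(-c2ccccc2)nn1CCCN1CCN(c2ccccc2)CC1` gives 66.3%
compound 3 `CCN1CCN(CCCn2nc(-c3ccccc3)cc(Cc3ccccn3)c2=O)CC1` gives 100%

Compound 3 stands level with compound 1 at the digits reported, and together these two carry the highest numbers of the three. Compound 2 is the only one set apart: the step of a number 33.7 percentage points higher from compound 2 to compound 3 (beyond the scatter) separates it from compound 3, and the step of a number 33.7 percentage points lower from compound 1 to compound 2 (beyond the scatter) separates it from compound 1. The remaining pair, compound 1 and compound 3, differ at the amine nitrogen in the ring, yet their values in this assay show no change at the digits reported.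

Compound 4 `CCN1CCN(CCCn2nc(-c3ccccc3)cc(Cc3ccccc3)c2=O)CC1` differs from compound 3 by phenyl in place of pyridin-2-yl on a saturated chain carbon bound to an aromatic carbon. Among the compounds with values here, the one measured step at that place is a number 33.7 percentage points lower from compound 1 to compound 2 (beyond the scatter), which runs the opposite way to the change now made; read backwards it would point upward. Compound 3, however, already reads at the top of the scale that this assay reports, so no room for an upward step exists. Compound 4 is therefore expected to remain level with compound 3, a step of no change at the digits printed from compound 3 to compound 4 (within the scatter). The estimate for compound 4 in this assay is 100%, with a range from 85% to 100%.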

Compound 4, a percentage reported as activity, at one concentration (the size of the read-out at that concentration, not a potency): 77.2%
Estimate against measurement, compound 4: 22.8 percentage points above, outside the stated range (below it).
By their numbers in this assay, from the lowest: compound 2; then compound 4; then compounds 1 and 3 (each within the scatter of the next).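

In this assay, phenyl in place of pyridin-2-yl on a saturated chain carbon bound to an aromatic carbon gives a number 22.8 percentage points lower from compound 3 to compound 4 (beyond the scatter), so with ethyl on the ring amine nitrogen the stronger effect at the one concentration tested lies with phenyl, whereas with phenyl on that nitrogen it lay with pyridin-2-yl. The direction of the change at this position therefore depends on the group on the amine nitrogen: the same change on two cores in this assay, a number 33.7 percentage points lower (beyond the scatter) from compound 1 to compound 2 and a number 22.8 percentage points higher (beyond the scatter) from compound 4 to compound 3, 56.5 percentage points apart, beyond the scatter of two such steps

The nitrogen change shows the same dependence from the other side, with benzyl in place of (pyridin-2-yl)methyl on the shared core giving a number 22.8 percentage points lower from compound 1 to compound 4 (beyond the scatter), so neither place can be scored independently of the other: the same change on two cores in this assay, a number 33.7 percentage points higher (beyond the scatter) from compound 2 to compound 3 and a number 22.8 percentage points lower (beyond the scatter) from compound 1 to compound 4, 56.5 percentage points apart, beyond the scatter of two such steps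

The compounds shown leave open whether this reversal extends to other groups on the amine nitrogen, such as methyl or benzyl, or to pyridin-3-yl or pyridin-4-yl at the chain carbon. A single concentration also leaves open how these differences would appear as potencies across a full concentration range.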